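Chalcone series: aryl swap at the chain end

The compounds below may be only part of what the source reports. "The series", "measured", "known", "first", "only" and "open" are said of these compounds alone.

Three measured compounds share one core and differ only in the aryl group on the double-bonded chain carbon. In a functional assay on SW-620 cells (Homo sapiens) for antiproliferative activity, read by MTT assay, with a stated time of 24 h (a lower number here means a stronger inhibitor, a higher number a weaker inhibitor), compound 1 `COc1ccc(C(=O)/C=C/c2ccc([N+](=O)[O-])cc2)c2c1C=CC(C)(C)O2` gives 3520 nM, and compound 2 `COc1ccc(C(=O)/C=C/c2cccc([N+](=O)[O-])c2)c2c1C=CC(C)(C)O2` gives 4090 nM; the step of a 1.2-fold higher number from compound 1 to compound 2 (0.07 log units; within the scatter) lies within the scatter. Compound 3 `COc1ccc(C(=O)/C=C/c2cccc(Cl)c2)c2c1C=CC(C)(C)O2` gives only a limit of the assay, > 10000 nM. On the numbers shown compound 3 therefore stands at the weak end, as the steps of an at least 2.8-fold higher number from compound 1 to compound 3 (0.45 log units; beyond the scatter) and an at least 2.4-fold higher number from compound 2 to compound 3 (0.38 log units; beyond the scatter) both raise the number at least modestly, and the bound is the one at the limit of > 10000 nM in this assay, at which 1 of the 3 values shown sits.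

Compound 4 `COc1ccccc1/C=C/C(=O)c1ccc(OC)c2c1OC(C)(C)C=C2` carries 2-methoxyphenyl in place of 3-chlorophenyl on a double-bonded chain carbon bound to a double-bonded chain carbon. Both steps that reach compound 3 describe the loss of a nitro group, not the gain of a methoxy group, so they bear on this change only indirectly: they show that the 3-chlorophenyl starting point is the weakest of the three, and a move away from it can be downward, or none beyond the scatter. The step expected for compound 4 is a number no higher from compound 3 to compound 4 (the limit leaves the size open). Compound 4 is estimated at 10000 nM, in a range of 3000 nM to 30000 nM.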

Compound 4, half-maximal inhibitory concentration: > 10000 nM
Compound 4: no number, only a limit (the forecaster's own chance of this, stated with the estimate: 50%); the middle value sits exactly at the limit.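

In this assay, the 2-methoxyphenyl group joins the 3-chlorophenyl group at the assay limit, so two of the aryl groups at this position now give no readable number: the limit of > 10000 nM in this assay, at which 2 of the 4 values shown sit. The change from either nitrophenyl group to 2-methoxyphenyl also weakens the result, with an at least 2.4-fold higher number from compound 2 to compound 4 (0.38 log units; beyond the scatter) and an at least 2.8-fold higher number from compound 1 to compound 4 (0.45 log units; beyond the scatter). Among the four compounds, only the two carrying a nitro group give a readable number, with no exception so far, while the step between compound 3 and compound 4 cannot be read.

On these data alone, how much weaker compound 3 and compound 4 really are, and which of the two is weaker, stays open. Also open, as far as these compounds go, is whether an amine or a carboxylic acid in place of the nitro group would give a readable number at this position.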